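The source may report more compounds than this note shows. Statements on the series, on what has been measured and on what is new or still open speak of the compounds shown alone.

Three ureas have been measured in an ADME assay on the whole organism with Oryza sativa as the target, tested at 0.1 uM; a higher number here means a weaker effect of the compound at the concentration tested, a lower number a stronger effect. Compound 1 `CC(C)c1ccccc1NC(=O)N[C@H](C)c1ccccc1` gives 103%. Compound 2 `C[C@@H](NC(=O)Nc1ccc(C(C)(C)C)cc1)c1ccccc1` gives 100%, and compound 3 `C[C@H](NC(=O)Nc1ccc(C(C)(C)C)cc1)c1ccccc1` gives 100%; the three numbers all lie within the scatter of one another, so none can be ranked. Going by the values given here, the only step between neighbours, no change at the digits printed from compound 2 to compound 3 (within the scatter), shows no change, which fits because the fact that compounds 2 and 3 differ only in the configuration as drawn is the whole difference. Compound 4 `CCCCCCCc1ccc(NC(=O)N[C@H](C)c2ccccc2)cc1` is not yet measured; it arises from compound 2 by heptyl in place of tert-butyl on an aromatic carbon. Among the compounds with values here, no measured step touches this group, so the outcome rests on the flat picture seen so far. Compound 4 is expected to give about 100%, somewhere between 88% and 110%, an expected step of no change at the digits printed from compound 2 to compound 4 (within the scatter), within the scatter.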

Compound 4, a percentage reported as activity, at one concentration (the size of the read-out at that concentration, not a potency): 100%
Compound 4: middle estimate and measured number agree at the digits printed, within the range that was stated.
By their numbers in this assay, from the lowest: compounds 2, 3, 4 and 1 (each within the scatter of the next).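

In this assay, going by these compounds alone, the first step at this aromatic carbon replaces tert-butyl with the longer heptyl and gives no change at the digits printed from compound 2 to compound 4 (within the scatter). So this place tolerates a swap between these two carbon-only groups, one branched and one a chain, without any readable shift in the number. Nothing known about these compounds bears on why this is so.

Still open, on these data alone, is whether a group of another kind on this carbon, such as an amine or a carboxylic acid, would move the number away from this flat level.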